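Thioether side-chain variation on the shared core

The source may report more compounds than this note shows. Statements on the series, on what has been measured and on what is new or still open speak of the compounds shown alone.

Measured so far:
- compound 1 `CC(C)c1n[nH]c2c(NCc3ccc(-c4ccccn4)cc3)nc(SCCC(N)=O)nc12`: 120 nM
- compound 2 `CC(O)CSc1nc(NCc2ccc(-c3ccccn3)cc2)c2[nH]nc(C(C)C)c2n1`: 62 nM
- compound 3 `CC(C)c1n[nH]c2c(NCc3ccc(-c4ccccn4)cc3)nc(SCC(O)CO)nc12`: 21 nM

In a functional assay on HT cells (Homo sapiens) for antiproliferative activity, read by fluorescence, with a stated time of 72 h (on this read-out lower numbers stand for stronger inhibition of growth and higher numbers for weaker inhibition of growth), compound 3 gives the lowest number of the three. The steps to it are a 5.7-fold lower number from compound 1 to compound 3 (0.76 log units; beyond the scatter) and a 3.0-fold lower number from compound 2 to compound 3 (0.47 log units; beyond the scatter), both beyond the scatter, whereas a 1.9-fold lower number from compound 1 to compound 2 (0.29 log units; within the scatter) stays within it. Compound 3 is therefore the strongest inhibitor of growth among the measured compounds.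

The next compound, compound 4 `CC(C)c1n[nH]c2c(NCc3ccc(-c4ccccn4)cc3)nc(SCCCN(C)C)nc12`, differs from compound 3 in the side chain on the sulfur: 2-(dimethylamino)ethyl in place of 1,2-dihydroxyethyl on a saturated chain carbon bound to a sulfur. Within the data shown here, none of the measured steps covers this exchange; all of them keep oxygen in the chain, and the only step that bears on it at all is the reverse of a 3.0-fold lower number from compound 2 to compound 3 (0.47 log units; beyond the scatter), which shows that taking away a hydroxy from that chain costs a modest amount. The new group carries no hydrogen-bond donor, so the step to compound 4 is expected to point toward a higher number, of modest size.

Compound 4 is expected to give 55 nM in this assay, within a range of 15 nM to 200 nM. This corresponds to an expected step of a 2.6-fold higher number from compound 3 to compound 4 (0.42 log units; beyond the scatter).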

Compound 4, concentration for 50% growth inhibition: 105 nM
Estimate against measurement, compound 4: 1.9-fold (0.28 log units) below; the range from low to high includes it.
By their numbers in this assay, from the lowest: compound 3; then compounds 2, 4 and 1 (each within the scatter of the next).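

In this assay, putting 2-(dimethylamino)ethyl, with 0 hydrogen-bond donors, in place of 1,2-dihydroxyethyl, with 2, gives a 5.0-fold higher number from compound 3 to compound 4 (0.70 log units; beyond the scatter) and shows that the lead of compound 3 also holds against a side chain with no oxygen in it. Against the other two side chains the new group makes no readable difference, with a 1.7-fold higher number from compound 2 to compound 4 (0.23 log units; within the scatter) and a 1.1-fold lower number from compound 1 to compound 4 (0.06 log units; within the scatter) both within the scatter, so that compounds 1, 2 and 4 stand level and, among the four compounds, only compound 3 separates from the rest, despite the different groups on that chain carbon. Nothing measured here accounts for the separation of compound 3 from the others.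

The compounds shown leave open whether a carboxylic acid or a primary amine on a saturated chain carbon bound to a sulfur would stand with compound 3 or with the level group of three. Also open, on these data alone, is whether a longer chain carrying two hydroxy groups would hold the value of compound 3 at 21 nM or fall back to that group.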